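Swapping the halogenated ring for a methylphenyl

The source may report more compounds than this note shows. Statements on the series, on what has been measured and on what is new or still open speak of the compounds shown alone.

The three measured compounds share one core and differ only in the aromatic ring attached to the nitrogen. Compound 1 `COc1cc(/C=C/C(=O)c2sc(Nc3ccc(Cl)cc3)nc2C)cc(OC)c1OC` carries a 4-chlorophenyl there, and in a functional assay on NCI-H460 cells (Homo sapiens) for cytotoxicity, read by MTT assay (a lower number here means a stronger inhibitor, a higher number a weaker inhibitor), compound 1 gives 22000 nM. Compound 2 `COc1cc(/C=C/C(=O)c2sc(Nc3cccc(Cl)c3)nc2C)cc(OC)c1OC` carries a 3-chlorophenyl; in this assay compound 2 reaches only the limit > 25000 nM, so no number is known for it. Compound 3 `COc1cc(/C=C/C(=O)c2sc(Nc3ccc(F)c(Cl)c3)nc2C)cc(OC)c1OC` carries a 3-chloro-4-fluorophenyl, and in this assay compound 3 gives 6310 nM, the lowest of the two numbers shown. The step of a 3.5-fold lower number from compound 1 to compound 3 (0.54 log units; beyond the scatter) is modest, and the step of an at least 3.9-fold lower number from compound 2 to compound 3 (0.59 log units; beyond the scatter) is at least modest; the step of an at least 1.1-fold higher number from compound 1 to compound 2 (0.05 log units; that floor lies within the scatter) cannot be sized because compound 2 sits at the limit of > 25000 nM in this assay, at which 1 of the 3 values shown sits.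

Compound 4 `COc1cc(/C=C/C(=O)c2sc(Nc3ccc(C)cc3)nc2C)cc(OC)c1OC` is not yet measured. Its change from compound 3 is 4-methylphenyl in place of 3-chloro-4-fluorophenyl on a nitrogen on an aromatic ring. Both halogens that set compound 3 apart leave, and a methylphenyl ring enters, so compound 4 resembles compound 1 more than compound 3 in what its ring carries. On that ground a step of about a 3.2-fold higher number from compound 3 to compound 4 (0.50 log units; beyond the scatter) is expected, back toward the weaker end. In this assay compound 4 is expected to give about 20000 nM, between 7000 nM and 60000 nM.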

Compound 4, half-maximal inhibitory concentration: > 25000 nM
Compound 4 ended at the assay's limit; the forecaster's own chance of this, stated with the estimate: 35%; at least 1.2-fold (0.09 log units) between middle value and limit.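

Putting 4-methylphenyl in place of 3-chloro-4-fluorophenyl on the nitrogen gives an at least 3.9-fold higher number from compound 3 to compound 4 (0.59 log units; beyond the scatter), so in this assay compound 3 is now set apart from all three of the other compounds by steps beyond the scatter, and it remains the strongest of the four. The methyl ring therefore does not keep what the 3-chloro-4-fluorophenyl ring provides, although the data shown cannot say which feature of that ring matters. Methyl in place of chloro gives an at least 1.1-fold higher number from compound 1 to compound 4 (0.05 log units; that floor lies within the scatter), and as that floor lies within the scatter, this swap shows no readable change, while the step between compound 2 and compound 4 cannot be read because both stand at a limit: the limit of > 25000 nM in this assay, at which 2 of the 4 values shown sit.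

The rings shown carry only chloro, fluoro or methyl, so it remains open whether 4-fluorophenyl alone, with no chloro, would match compound 3. Going by these compounds, it is also open whether a methoxy, a trifluoromethyl or an amine on this ring would give a lower number than compound 3 or fall back to the limit.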